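Removing the Halogens from the Aryl Hydrazone of Compound 1

The source may hold more compounds than are shown below. What is called first, only, known or untested is meant among the compounds shown, and "the series" means these compounds.

Within the data shown here, compound 1 `CN(C)CCn1cnnc1-c1cc(Oc2ccc(NC(=O)N/N=C/c3ccc(F)cc3Cl)cc2F)ccn1` gives 870 nM in a functional assay on MKN-45 cells (Homo sapiens) for cytotoxicity, read by MTT assay, with a stated time of 72 h (a higher number here means a weaker inhibitor, a lower number a stronger inhibitor), the lowest of the three numbers known here. Compound 2 `CN(C)CCn1cnnc1-c1cc(Oc2ccc(NC(=O)N/N=C/c3cc(Br)c(O)c(Br)c3)cc2F)ccn1` gives 4320 nM, and compound 3 `COc1ccc(/C=N/NC(=O)Nc2ccc(Oc3ccnc(-c4nncn4CCN(C)C)c3)c(F)c2)c(OC)c1` gives 1680 nM. The step of a 5.0-fold higher number from compound 1 to compound 2 (0.70 log units; beyond the scatter) is modest, while the step of a 1.9-fold higher number from compound 1 to compound 3 (0.29 log units; within the scatter) stays within the scatter. Compound 4 `CN(C)CCn1cnnc1-c1cc(Oc2ccc(NC(=O)N/N=C/c3ccccc3)cc2F)ccn1` differs from compound 1 by phenyl in place of 2-chloro-4-fluorophenyl on a carbon with a double bond to nitrogen. Among the measured compounds shown here, no measured step strips this ring bare, but the two known exchanges on the same carbon move the number only moderately, and neither lowers it beyond the scatter. Compound 4 is therefore expected to give a somewhat higher number, a step of a 1.7-fold higher number from compound 1 to compound 4 (0.24 log units; within the scatter), estimated at 1500 nM with a range from 600 nM to 4000 nM.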

Compound 4, half-maximal inhibitory concentration: 2730 nM
The estimate for compound 4 lay 1.8-fold (0.26 log units) below the measured number, and the stated range covers the measured number.
By their numbers in this assay, from the lowest: compounds 1, 3, 4 and 2 (each within the scatter of the next, the first and the last beyond it).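

With the ring stripped bare, the step is a 3.1-fold higher number from compound 1 to compound 4 (0.50 log units; beyond the scatter), so among these compounds the lowest number goes with the two halogens of 2-chloro-4-fluorophenyl on this carbon. The bare phenyl stays within the scatter of both other rings, with a 1.6-fold higher number from compound 3 to compound 4 (0.21 log units; within the scatter) and a 1.6-fold lower number from compound 2 to compound 4 (0.20 log units; within the scatter), so neither 2,4-dimethoxyphenyl nor 3,5-dibromo-4-hydroxyphenyl shows a gain over the unsubstituted ring. Whether the chlorine or the fluorine alone accounts for the step remains open, as does the standing of a ring bearing an amine or a carboxylic acid. Nothing available here explains the step.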